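Chloro in Place of Methoxy on the Fused Ring

The compounds below may be only part of what the source reports. "The series", "measured", "known", "first", "only" and "open" are said of these compounds alone.

Compound 1 `COc1ccc(/C=C/c2cc(OC)cc(OC)c2/C=C/C(=O)c2cc3ccccc3oc2=O)cc1` gives 41700 nM in an assay on isolated protein for inhibition of Amine oxidase [flavin-containing] A (Homo sapiens), read by fluorescence, with a stated time of 15 min; a lower number here means a stronger inhibitor, a higher number a weaker inhibitor.
Compound 2 `COc1ccc(/C=C/c2cc(OC)cc(OC)c2/C=C/C(=O)c2cc3ccc(Cl)cc3oc2=O)cc1` gives the limit > 60000 nM in this assay, not a number.
Compound 3 `COc1ccc(/C=C/c2cc(OC)cc(OC)c2/C=C/C(=O)c2cc3cc(OC)ccc3oc2=O)cc1` gives the limit > 60000 nM in this assay, not a number.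

Compound 3 thus stands at the edge of what this assay can report, together with compound 2, while compound 1 alone has a measured number. Compound 4 `COc1ccc(/C=C/c2cc(OC)cc(OC)c2/C=C/C(=O)c2cc3cc(Cl)ccc3oc2=O)cc1` differs from compound 3 by chloro in place of methoxy on an aromatic carbon. Going by the values given here, two steps bear on this change: an at least 1.4-fold higher number from compound 1 to compound 3 (0.15 log units; that floor lies within the scatter) and an at least 1.4-fold higher number from compound 1 to compound 2 (0.15 log units; that floor lies within the scatter), both ending at the limit of > 60000 nM in this assay, at which 2 of the 3 values shown sit. Both added groups left the number no lower than that of compound 1, so no step beyond the scatter is expected here, in either direction. Compound 4 is therefore expected at 70000 nM, within 30000 nM to 200000 nM, an estimated step that the limit leaves unreadable from compound 3 to compound 4.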

Compound 4, half-maximal inhibitory concentration: > 60000 nM
Compound 4: no number, only a limit; the forecaster's own chance of this, stated with the estimate: 70%; the middle value lies beyond the limit too.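

With chloro or methoxy on this aromatic carbon, the result is the same: neither group gives a measured number in this assay. Against hydrogen on this carbon, the only reading is an at least 1.4-fold higher number from compound 1 to compound 4 (0.15 log units; that floor lies within the scatter), so no real difference from compound 1 is shown. The steps to compound 4 from compound 2 and from compound 3 cannot be read, because of where these values sit: the limit of > 60000 nM in this assay, at which 3 of the 4 values shown sit.

As far as these compounds go, whether an amine or a carboxylic acid on this carbon would give a measurable number stays open. So does the true distance of compound 4 from compound 1.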